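A few compounds are considered here, and "the series" means these few. Any claim that something is new, unique, unknown or untested is made for them only; others in the source may bear on it.

The three measured compounds share a core built from a diene amide linked to a pyridine-bearing chain. In a functional assay on the whole organism for inhibition, with Cavia porcellus as the target, with a stated time of 2 h (on this read-out higher numbers stand for an effect only at larger amounts of compound and lower numbers for an effect already at smaller amounts), compound 1 `CC[C@H](CCCc1cccnc1)NC(=O)/C=C/C=C(c1ccc(OC)cc1)c1ccc(OC)cc1` gives 6 mg/kg, the lowest of the three numbers. Compound 2 `CCCCCCCC/C(=C\C=C\C(=O)N[C@H](C)CCCc1cccnc1)c1ccc(OC)cc1` gives 13 mg/kg in this assay, and compound 3 `COc1ccc(C(=C/C=C/C(=O)NCCCCc2cccnc2)c2ccc(OC)c(OC)c2)cc1OC` gives 27 mg/kg. Both gaps from compound 1 lie beyond the usual scatter, so compound 1 is the most potent of the three here.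

Compound 4 `COc1ccc(C(=C/C=C/C(=O)NCCCCc2cccnc2)c2ccc(OC)cc2)cc1` has not yet been measured. It differs from compound 1 by one change: hydrogen in place of ethyl on a saturated chain carbon bound to an amide-type nitrogen and a saturated chain carbon. Among the compounds with values here, no measured pair shows this exact change on its own. Among the measured compounds, the unbranched chain appears only in compound 3, which also carries extra methoxy groups and gives 27 mg/kg, so the effect of the chain change by itself cannot be separated out. The step of a 2.0-fold higher number from compound 1 to compound 4 (0.30 log units; within the scatter) is expected to be small, toward a higher number, near the edge of the scatter. In this assay compound 4 is expected to give about 12 mg/kg, within a range from 5 mg/kg to 30 mg/kg.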

Compound 4, dose for 50% inhibition: 12 mg/kg
Compound 4: the middle estimate sits on the measured number at the digits printed, within the range that was stated.
By their numbers in this assay, from the lowest: compounds 1, 4 and 2 (each within the scatter of the next, the first and the last beyond it); then compound 3.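

In this assay, the exchange of ethyl for hydrogen on a saturated chain carbon bound to an amide-type nitrogen and a saturated chain carbon can now be read on its own, free of other changes, and it gives a 2.0-fold higher number from compound 1 to compound 4 (0.30 log units; within the scatter). At this position, then, compound 1 and compound 4 cannot be told apart, so the ethyl group is not shown to matter for this read-out. No independent measurement is available to explain this result.

As far as these compounds go, whether a longer chain such as butyl, or a group of another kind such as an amine or a carboxylic acid, would also stay within the scatter at this position remains open. From the compounds shown here alone, it is also open whether the same exchange would give a similar step on a different core.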